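From 4-methylphenyl to 4-chlorophenyl: notes on compound 3

This account rests on a few compounds, and the source may have more. Where it says the series, first, only, none or still open, it means among the compounds named here.

Measured so far in a functional assay on L1210 cells (Mus musculus) for inhibition, read by cell counting, with a stated time of 48 h; a lower number here means a stronger inhibitor, a higher number a weaker inhibitor:
- compound 1 `CCN(CC)CN1C(=O)/C(=N/NC(N)=S)c2cc(Cl)ccc21`: 148000 nM
- compound 2 `CCN(CC)CN1C(=O)/C(=N/NC(=S)Nc2ccc(C)cc2)c2cc(Cl)ccc21`: 9500 nM

Of the two measured compounds, compound 2 has the lower number at 9500 nM, making it the stronger inhibitor in this assay. Among the compounds with values here, the only measured step, a 16-fold lower number from compound 1 to compound 2 (1.19 log units; beyond the scatter), is large and places 4-methylphenyl where hydrogen stood on an amide-type nitrogen. Compound 3 `CCN(CC)CN1C(=O)/C(=N/NC(=S)Nc2ccc(Cl)cc2)c2cc(Cl)ccc21` keeps that ring but carries chloro in place of methyl on an aromatic carbon, para to a large group: chloro in place of methyl on an aromatic carbon. Within the data shown here, the step to compound 2 bears on this only indirectly, as no measured pair varies the group on that ring. With no evidence for either direction, no step beyond the scatter is expected in this assay. The expected step is a 1.1-fold lower number from compound 2 to compound 3 (0.02 log units; within the scatter). Compound 3 is estimated at 9000 nM, with an expected range of 3500 nM to 23000 nM.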

Compound 3, half-maximal inhibitory concentration: > 125000 nM
Compound 3: only a limit was reported; the forecaster's own chance of this, stated with the estimate: 3%; middle value at least 13-fold (1.14 log units) from the limit.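

In this assay compound 3 is reported only as a limit, > 125000 nM. Chloro in place of methyl on the aromatic carbon gives an at least 13-fold higher number from compound 2 to compound 3 (1.11 log units; beyond the scatter), so the gain seen with 4-methylphenyl does not carry over to 4-chlorophenyl, and an aryl group on that nitrogen is not enough in itself: the group at this place on the ring decides the outcome. The step between compound 1 and compound 3 cannot be read, and compound 3 stays bounded on one side only: the limit of > 125000 nM in this assay, at which 1 of the 3 values shown sits.

As far as these compounds go, whether this outcome belongs to chloro alone, or to any group other than methyl at this place, remains open; a methoxy group or an amine there would bear on it. Also open, from the compounds shown here alone, is whether a longer chain, such as ethyl or propyl, would hold the number of compound 2.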